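The source may report more compounds than this note shows. Statements on the series, on what has been measured and on what is new or still open speak of the compounds shown alone.

Measured so far:
compound 1, `COc1cc(Cl)cc(-c2nn(-c3cccc(NC(=O)Nc4ccc(Cl)c(C(F)(F)F)c4)c3)cc2-c2ccncc2)c1`, 89%;
compound 2, `COc1cc(Cl)cc(-c2nn(-c3cccc(NC(=O)Nc4ccc(Cl)c(Cl)c4)c3)cc2-c2ccncc2)c1`, 88%.

Both numbers come from a functional assay on NCI-H322M cells (Homo sapiens) for inhibition, read by sulforhodamine B assay, with a stated time of 48 h, tested at 1 uM; a higher number here means a weaker effect of the compound at the concentration tested, a lower number a stronger effect. Compound 2 gives the lower of the two values, but the step of a number 1 percentage points lower from compound 1 to compound 2 (within the scatter) is within the scatter, so the two compounds cannot be ranked against each other.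

Compound 3, `COc1cc(Cl)cc(-c2nn(-c3cccc(NC(=O)Nc4cccc(C(F)(F)F)c4)c3)cc2-c2ccncc2)c1`, is not yet measured. It differs from compound 2 by 3-(trifluoromethyl)phenyl in place of 3,4-dichlorophenyl on an amide-type nitrogen. Going by the values given here, the only step available for comparison, a number 1 percentage points lower from compound 1 to compound 2 (within the scatter), swapped chloro for trifluoromethyl on an aromatic carbon and changed nothing beyond the scatter; the present change also removes one chloro substituent altogether, for which no step exists. On that basis no step beyond the scatter is expected in this assay, the estimated step being a number 1 percentage points higher from compound 2 to compound 3 (within the scatter). Compound 3 is therefore estimated at 89%, with a range from 76% to 100%.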

Compound 3, a percentage reported as activity, at one concentration (the size of the read-out at that concentration, not a potency): 83%
For compound 3 the middle estimate is 6 percentage points above the measured one, within the range that was stated.
By their numbers in this assay, from the lowest: compounds 3, 2 and 1 (each within the scatter of the next).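

Until now, the aryl group on the amide-type nitrogen had only seen one substituent exchanged for another; compound 3 adds the removal of a substituent. In this assay, removing the chloro gives a number 6 percentage points lower from compound 1 to compound 3 (within the scatter), and replacing 3,4-dichlorophenyl with 3-(trifluoromethyl)phenyl gives a number 5 percentage points lower from compound 2 to compound 3 (within the scatter), so neither change moves the read-out beyond the scatter. Nothing available accounts for these small steps.

The three compounds therefore cannot be ranked, and they show no substituent at this place that changes the read-out beyond the scatter. On these data alone, whether a carboxylic acid, a dimethylamino group or a plain unsubstituted phenyl at this place would do so remains open, as does the effect of changes elsewhere on the shared core.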